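From phenoxy to phenyl on the shared core

This account rests on a few compounds, and the source may have more. Where it says the series, first, only, none or still open, it means among the compounds named here.

Measured in a physicochemical assay for solubility, with a stated time of 18 h, at pH 7.4; a higher number here means a more soluble compound, a lower number a less soluble compound:
compound 1 `Cc1cc(C)cc(Cc2ccc3c(NCCCNCc4ccco4)ccnc3c2)c1`: 4200 nM
compound 2 `COc1cccc(Oc2ccc3c(NCCCNCc4ccco4)ccnc3c2)c1`: 14500 nM
compound 3 `c1ccc(Oc2ccc3c(NCCCNCc4ccco4)ccnc3c2)cc1`: 14500 nM

Compound 3 stands level with compound 2, together the highest of the three numbers. Compound 4 `c1ccc(-c2ccc3c(NCCCNCc4ccco4)ccnc3c2)cc1` is still unmeasured and carries phenyl in place of phenoxy on an aromatic carbon. Among the compounds with values here, no measured step makes this exchange directly. The nearest evidence is modest, a 3.5-fold higher number from compound 1 to compound 3 (0.54 log units; beyond the scatter), with a 3.5-fold higher number from compound 1 to compound 2 (0.54 log units; beyond the scatter) alongside it, while the loss of methoxy gave no change at the digits printed from compound 2 to compound 3 (within the scatter). In this assay, a small downward step is therefore expected, possibly none beyond the scatter. The expected change is a 1.5-fold lower number from compound 3 to compound 4 (0.16 log units; within the scatter). Compound 4 is estimated at 10000 nM, with an expected range of 4500 nM to 21000 nM.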

Compound 4, solubility: 32000 nM
The estimate for compound 4 lay 3.2-fold (0.51 log units) below the measured number; measured number above the stated range.
By their numbers in this assay, from the lowest: compound 1; then compounds 2 and 3 (each within the scatter of the next); then compound 4.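

In this assay this position turns out to tolerate a further rise: phenyl in place of phenoxy gives a 2.2-fold higher number from compound 3 to compound 4 (0.34 log units; beyond the scatter) and phenyl in place of 3-methoxyphenoxy gives a 2.2-fold higher number from compound 2 to compound 4 (0.34 log units; beyond the scatter), so dropping the oxygen-linked ring for a directly attached phenyl moves the number where losing methoxy did not. Phenyl in place of 3,5-dimethylbenzyl gives a 7.6-fold higher number from compound 1 to compound 4 (0.88 log units; beyond the scatter), which leaves compound 4 highest of the four, beyond the scatter from each of the others. On these data alone, whether an amine or a carboxylic acid on this aromatic carbon would go higher stays open. Nothing shown here accounts for the rise.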